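This account rests on a few compounds, and the source may have more. Where it says the series, first, only, none or still open, it means among the compounds named here.

Compound 1 `O=C(/C=C\c1ccc(O)cc1)N1N=C(c2ccncc2)OC1c1c[nH]c2ccccc12` gives in an ADME assay on HeLa cells (Homo sapiens) for cytotoxicity, read by MTT assay, with a stated time of 72 h (a lower number here means a stronger inhibitor of growth, a higher number a weaker inhibitor of growth), a value of > 30 ug/mL, which is a limit of the assay rather than a number.
Compound 2 `O=C(/C=C\c1ccccc1[N+](=O)[O-])N1N=C(c2ccncc2)OC1c1c[nH]c2ccccc12` gives in this assay a value of > 30 ug/mL, again a limit of the assay.
Compound 3 `Cc1ccc(/C=C\C(=O)N2N=C(c3ccncc3)OC2c2c[nH]c3ccccc23)cc1` gives in this assay a value of > 30 ug/mL, also a limit of the assay.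

Compound 3 therefore stands at the same point as the other two compounds, since (the limit of > 30 ug/mL in this assay, at which 3 of the 3 values shown sit). Every value is a limit. None of the steps between these compounds can be read: a step that the two limits leave unreadable from compound 1 to compound 2, a step that the two limits leave unreadable from compound 1 to compound 3 and a step that the two limits leave unreadable from compound 2 to compound 3 all stay unreadable in size.

Compound 4 `O=C(/C=C\c1cccc(Br)c1)N1N=C(c2ccncc2)OC1c1c[nH]c2ccccc12` differs from compound 3 in one place: 3-bromophenyl in place of 4-methylphenyl on a double-bonded chain carbon bound to a double-bonded chain carbon. For the measured compounds named here, no measured step concerns a 3-bromophenyl group, so the only guidance is that each change made so far on this double-bonded chain carbon left the compound at the limit. The step that the limit leaves unreadable from compound 3 to compound 4 is thus expected to be none beyond the scatter, with another limit the most likely outcome. Compound 4 is expected to give about 35 ug/mL, within a range from 20 ug/mL to 60 ug/mL.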

Compound 4, concentration for 50% growth inhibition: > 30 ug/mL
Compound 4 gave a limit, no number (the forecaster's own chance of this, stated with the estimate: 80%); the middle value is on the limit's open side.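

Compound 4 also sits at a limit of the assay, so no step among compound 1, compound 2, compound 3 and compound 4 can be read: the limit of > 30 ug/mL in this assay, at which 4 of the 4 values shown sit.

The compounds shown leave open whether these four groups on the double-bonded chain carbon differ at all in how strongly they inhibit growth.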